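Methoxy added to a phenoxy group: expected solubility

The source may hold more compounds than are shown below. What is called first, only, known or untested is meant among the compounds shown, and "the series" means these compounds.

Measured compounds:
compound 1, `COc1ccc(Oc2ccc3c(NCCCNCc4cc(F)ccc4OC)ccnc3c2)cc1`, 14500 nM
compound 2, `c1ccc(Oc2ccc3c(NCCCNCc4ccco4)ccnc3c2)cc1`, 14500 nM

Of the compounds shown here, two have been measured in a physicochemical assay for solubility, with a stated time of 18 h, at pH 7.4; on this read-out lower numbers stand for lower solubility and higher numbers for higher solubility. Compound 1, whose structure is `COc1ccc(Oc2ccc3c(NCCCNCc4cc(F)ccc4OC)ccnc3c2)cc1`, gives 14500 nM in this assay. Compound 2, whose structure is `c1ccc(Oc2ccc3c(NCCCNCc4ccco4)ccnc3c2)cc1`, gives 14500 nM in this assay. The two values are level at the digits shown, so compound 2 stands with compound 1 and no ordering between them can be read from these numbers.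

Compound 3, whose structure is `COc1ccc(Oc2ccc3c(NCCCNCc4ccco4)ccnc3c2)cc1`, has not yet been measured in this assay. It differs from compound 2 in one place: methoxy in place of hydrogen on an aromatic carbon. Compound 1 carries the same 4-methoxyphenoxy group as compound 3, and its value sits level with that of compound 2, which lacks the methoxy. Within the data shown here, no measured pair shares this exact change, so the direction of the step is open. The expectation is therefore a small step, a 1.2-fold lower number from compound 2 to compound 3 (0.08 log units; within the scatter), within the scatter. Compound 3 is estimated to give 12000 nM, expected between 5000 nM and 28000 nM.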

Compound 3, solubility: 14500 nM
The estimate for compound 3 lay 1.2-fold (0.08 log units) below the measured number; measured number inside the range.
By their numbers in this assay, from the lowest: compounds 1, 2 and 3 (each within the scatter of the next).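

In this assay, methoxy in place of hydrogen on an aromatic carbon of the phenoxy group, para to a large group, gives no change at the digits printed from compound 2 to compound 3 (within the scatter). Among these compounds, this is the first pair that isolates the methoxy at this position, and the step lies within the scatter, so this single comparison gives no sign that adding the group here alters the read-out. A second single change, at a different place, has a similar outcome: furan-2-yl in place of 5-fluoro-2-methoxyphenyl on a saturated chain carbon bound to an amine nitrogen gives no change at the digits printed from compound 1 to compound 3 (within the scatter), and nothing in the data offers a reason for either result.

Among the compounds shown here, these pairs test only one group at each place, so it remains open whether an amine, a carboxylic acid or a longer chain such as ethoxy on the same aromatic carbon would also stay within the scatter. On these data alone, it is also open whether the methoxy step would look the same with the 5-fluoro-2-methoxyphenyl group in place of furan-2-yl, since each step has been read in only one setting.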